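A methoxyphenyl variant of a kinase-type amide series

The source may report more compounds than this note shows. Statements on the series, on what has been measured and on what is new or still open speak of the compounds shown alone.

The measured compounds:
Compound 1, `COc1cc2c(Oc3ccc(NC(=O)c4cc(-c5ccc(F)cc5)ccn4)cc3F)ccnc2cc1OCCCN1CCN(C)CC1`, gives 430 nM.
Compound 2, `COc1cc2c(Oc3ccc(NC(=O)c4cc(-c5ccccc5F)ccn4)cc3F)ccnc2cc1OCCCN1CCN(C)CC1`, gives 140 nM.

Both numbers come from a functional assay on NCI-H460 cells (Homo sapiens) for cytotoxicity, read by MTT assay, with a stated time of 72 h; on this read-out lower numbers stand for stronger inhibition and higher numbers for weaker inhibition. Going by the values given here, compound 2 holds the lowest of the two numbers; its nearest neighbour is compound 1, and the only step recorded here, a 3.1-fold lower number from compound 1 to compound 2 (0.49 log units; beyond the scatter), is modest but beyond the scatter.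

Compound 3, `COc1ccc(-c2ccnc(C(=O)Nc3ccc(Oc4ccnc5cc(OCCCN6CCN(C)CC6)c(OC)cc45)c(F)c3)c2)cc1`, has not yet been measured in this assay. Compared with compound 2 it carries a 4-methoxyphenyl in place of 2-fluorophenyl on an aromatic carbon. The group leaving has a fluorine; the group entering has a methoxy with one hydrogen-bond acceptor, placed meta to a large group and opposite the ring nitrogen of the six-membered aromatic ring with 1 nitrogen.

Among the compounds with values here, only one measured step bears on this change, the one from compound 1 to compound 2, and it tells what moving a fluorine around the phenyl does, not what a methoxy does. The expectation therefore rests mainly on the spread already seen between compound 1 and compound 2. Compound 3 is expected to land in this assay at 350 nM, within 120 nM to 1000 nM, a step of a 2.5-fold higher number from compound 2 to compound 3 (0.40 log units; beyond the scatter).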

Compound 3, half-maximal inhibitory concentration: 370 nM
Compound 3: the middle estimate sits 1.1-fold (0.02 log units) below what was measured; the measured number falls inside the stated range.
By their numbers in this assay, from the lowest: compound 2; then compounds 3 and 1 (each within the scatter of the next).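

In this assay, putting a 4-methoxyphenyl in place of the 2-fluorophenyl on this aromatic carbon, opposite the ring nitrogen, gives a 2.6-fold higher number from compound 2 to compound 3 (0.42 log units; beyond the scatter) as a modest step, so the lowest number among the compounds shown stays with the 2-fluorophenyl. Methoxy in place of fluoro on the phenyl gives a 1.2-fold lower number from compound 1 to compound 3 (0.07 log units; within the scatter) and so leaves no readable difference between the 4-fluorophenyl and the 4-methoxyphenyl, which means that this exchange, unlike the earlier shift of the fluorine, does not move the number beyond the scatter. No measurement at hand bears on what lies behind these differences.

Going by these compounds alone, the three compounds do not settle whether the lower number of compound 2 belongs to the placement of the group on the phenyl or to the fluorine itself, since fluorine is the only group seen in that placement. A 2-methoxyphenyl would separate those two readings, while an unsubstituted phenyl would show whether the fluorine or the methoxy is needed at all.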